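A few compounds are considered here, and "the series" means these few. Any claim that something is new, unique, unknown or untested is made for them only; others in the source may bear on it.

- compound 1 `COc1ccc(S(=O)(=O)N2CCc3cccc(-c4ccc(F)c(F)c4)c32)cc1` - 46 nM
- compound 2 `COc1ccc(-c2cccc3c2N(S(=O)(=O)c2ccc(OC)cc2)CC3)cc1` - 302 nM

In a functional assay on NCI-H460 cells (Homo sapiens) for inhibition, with a stated time of 72 h (on this read-out lower numbers stand for stronger inhibition and higher numbers for weaker inhibition), compound 1 at 46 nM stands lowest of the two measured compounds. Compound 3 `COc1ccc(S(=O)(=O)N2CCc3cccc(-c4cccnc4)c32)cc1` differs from compound 1 in one group (pyridin-3-yl in place of 3,4-difluorophenyl on an aromatic carbon). Among the measured compounds shown here, the only measured step at this place (a 6.6-fold higher number from compound 1 to compound 2 (0.82 log units; beyond the scatter)) also removes 3,4-difluorophenyl; it was modest and beyond the scatter. A step of similar or somewhat smaller size is therefore expected in this assay, toward a higher number. For the measured compounds named here, no measured compound carries pyridin-3-yl, so the range stays wide. The expected change is a 4.3-fold higher number from compound 1 to compound 3 (0.64 log units; beyond the scatter) on this estimate. The estimated value for compound 3 is 200 nM (range 60 nM to 700 nM).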

Compound 3, half-maximal inhibitory concentration: 89.6 nM
Compound 3: the middle estimate sits 2.2-fold (0.35 log units) above what was measured; low and high end bracket the measured number.
By their numbers in this assay, from the lowest: compounds 1 and 3 (each within the scatter of the next); then compound 2.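

In this assay, pyridin-3-yl on this aromatic carbon gives a number within the scatter of the 3,4-difluorophenyl compound (a 1.9-fold higher number from compound 1 to compound 3 (0.29 log units; within the scatter)), so the two fluorines and an all-carbon ring are not required here. The weaker number of compound 2 is therefore specific to 4-methoxyphenyl among these three groups (a 3.4-fold lower number from compound 2 to compound 3 (0.53 log units; beyond the scatter)).

As far as these compounds go, whether this position needs an aromatic ring at all remains open, as does how a piperidine ring, an amine or a carboxylic acid here would compare. No measured evidence bears on the reason for these steps.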